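The source may hold more compounds than are shown below. What is called first, only, known or untested is meant among the compounds shown, and "the series" means these compounds.

Compound 1 `O=C1c2c[n+]([O-])c3ccccc3c2C(=O)c2c1c1ccccc1n2Cc1cn(C[C@H](O)CO)nn1` is the reference point of this small set. For the measured compounds named here, in a functional assay on A-375 cells (Homo sapiens) for cytotoxicity, read by MTT assay, with a stated time of 72 h (on this read-out lower numbers stand for stronger inhibition and higher numbers for weaker inhibition), compound 1 gives 350 nM, the highest of the three numbers measured so far. Compound 2 `CC1(C)O[C@@H](CO)[C@H](Cn2cc(Cn3c4c(c5ccccc53)C(=O)c3c[n+]([O-])c5ccccc5c3C4=O)nn2)O1` gives 190 nM in this assay, and compound 3 `CC1(C)OC[C@H](Cn2cc(Cn3c4c(c5ccccc53)C(=O)c3c[n+]([O-])c5ccccc5c3C4=O)nn2)O1` gives 180 nM. The three known steps all vary the substituent on the triazole while keeping the triazole itself: a 1.8-fold lower number from compound 1 to compound 2 (0.27 log units; within the scatter), a 1.9-fold lower number from compound 1 to compound 3 (0.29 log units; within the scatter) and a 1.1-fold lower number from compound 2 to compound 3 (0.02 log units; within the scatter). None of them leaves the scatter, so across this series the group beyond the triazole has made no difference that can be trusted.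

Compound 4 `CN(C)CCCCn1c2c(c3ccccc31)C(=O)c1c[n+]([O-])c3ccccc3c1C2=O` departs from compound 1 in a different way: 3-(dimethylamino)propyl in place of 1-(2,3-dihydroxypropyl)-1H-1,2,3-triazol-4-yl on a saturated chain carbon bound to an aromatic nitrogen. Here the triazole and both hydroxyls leave, and a short basic chain enters in their place. Going by the values given here, no measured step removes the triazole, so the known steps bear on this change only by showing that the tail region tolerates variation without a shift beyond the scatter. On that basis no step beyond the scatter is firmly expected in this assay, though a move toward a lower number is judged somewhat more likely than a move upward; the estimated step is a 1.8-fold lower number from compound 1 to compound 4 (0.24 log units; within the scatter). Compound 4 is therefore expected to give about 200 nM, within a range of 60 nM to 700 nM.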

Compound 4, half-maximal inhibitory concentration: 470 nM
Beside the measured number, compound 4's estimate is 2.4-fold (0.37 log units) below it, within the range that was stated.
By their numbers in this assay, from the lowest: compounds 3, 2, 1 and 4 (each within the scatter of the next, the first and the last beyond it).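

In this assay, for the compounds shown here, the earlier steps all kept the triazole, whereas this step replaces 1-(2,3-dihydroxypropyl)-1H-1,2,3-triazol-4-yl with 3-(dimethylamino)propyl and still gives only a 1.3-fold higher number from compound 1 to compound 4 (0.13 log units; within the scatter). On a saturated chain carbon bound to an aromatic nitrogen, compound 1 and compound 4 therefore cannot be told apart, even though the triazole ring, both hydroxyls and the defined stereocentre all leave and a ringless chain with a terminal amine enters. The tolerance of this place thus extends, for this pair, beyond changes to the group carried on the triazole, but nothing available explains why the two tails give indistinguishable numbers.

The compounds shown leave open whether the terminal dimethylamino group contributes anything of its own, which a 4-hydroxybutyl chain, a plain butyl chain or a carboxylic acid at the same chain end could test. They also leave open how far this tolerance extends, including whether a longer chain, a shorter chain or a piperidine ring in place of the dimethylamino group would stay within the scatter of compound 4.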